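A few compounds are considered here, and "the series" means these few. Any claim that something is new, unique, unknown or untested is made for them only; others in the source may bear on it.

Compound 1, `CCCc1c[nH]c2ccc(F)cc12`; compound 2, `NC(=O)CCCCc1c[nH]c2ccc(F)cc12`; compound 3, `NC(=O)CCc1c[nH]c2c(F)cccc12`.

In an assay on isolated protein for inhibition of Myeloperoxidase (Homo sapiens), read by ELISA, with a stated time of 5 min (a lower number here means a stronger inhibitor, a higher number a weaker inhibitor), compound 1 gives only a limit of the assay, > 100 nM. In this assay compound 2 gives 43 nM. Compound 3 gives 64 nM, a number within the usual scatter of that of compound 2, so the two cannot be told apart.

The unmeasured compound 4, `NCC(N)CCc1c[nH]c2ccc(F)cc12`, differs from compound 2 in one place: 1,2-diaminoethyl in place of 2-carbamoylethyl on a saturated chain carbon, two bonds along the chain from an aromatic carbon.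

Within the data shown here, only one measured step concerns this part of the molecule: an at least 2.3-fold lower number from compound 1 to compound 2 (0.36 log units; beyond the scatter), where the number for compound 1 is a limit (the limit of > 100 nM in this assay, at which 1 of the 3 values shown sits). That step shows that adding the carbamoyl-bearing chain end helped at least modestly. Among the measured compounds shown here, compound 4 removes that chain end and carries a 1,2-diaminoethyl instead, a change for which no measured step exists, so the expectation rests on weak ground. The expected step is a 2.8-fold higher number from compound 2 to compound 4 (0.45 log units; beyond the scatter), a modest weakening. For compound 4 the estimate in this assay is 120 nM, with a range from 30 nM to 500 nM.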

Compound 4, half-maximal inhibitory concentration: 26 nM
Compound 4: the middle estimate sits 4.6-fold (0.66 log units) above what was measured; measured number outside the range, below it.
By their numbers in this assay, from the lowest: compounds 4, 2 and 3 (each within the scatter of the next, the first and the last beyond it). At a limit, above all of these: compound 1.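

In this assay, the carbonyl of the chain end in compound 2 is not required at this position: a 1.7-fold lower number from compound 2 to compound 4 (0.22 log units; within the scatter), and 1,2-diaminoethyl and 2-carbamoylethyl cannot be told apart here. Set against compound 1, 1,2-diaminoethyl also gives a gain beyond the scatter: an at least 3.8-fold lower number from compound 1 to compound 4 (0.58 log units; beyond the scatter). Compound 1 gives a limit of the assay, so the true size of that gain stays unknown: the limit of > 100 nM in this assay, at which 1 of the 4 values shown sits.

The compounds shown leave open whether both amines of 1,2-diaminoethyl are needed, a question that a chain ending in a single amine would address. They also leave open how a carboxylic acid at this place, or a longer chain carrying the two amines, would read in this assay.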